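Swapping the acyl group of compound 3 for a smaller one

This account rests on a few compounds, and the source may have more. Where it says the series, first, only, none or still open, it means among the compounds named here.

The series shares one core, seen in compound 1 `O=c1[nH]c2ccc(Cl)cc2c(-c2ccccc2Cl)c1CCO`, compound 2 `O=c1c(CCO)c(-c2ccccc2Cl)c2cc(Cl)ccc2n1-c1c(F)cccc1F` and compound 3 `O=C(OCCc1c(-c2ccccc2Cl)c2cc(Cl)ccc2[nH]c1=O)c1ccc([N+](=O)[O-])cc1`. In an ADME assay on HepG2 2.2.15 cells (Homo sapiens) for cytotoxicity (on this read-out higher numbers stand for lower toxicity in this test and lower numbers for higher toxicity in this test), compound 1 gives 380000 nM. Compound 2 reaches only a limit of this assay, > 2300000 nM, which is not a number. For the measured compounds named here, compound 3 gives 1600000 nM, the highest of the two numbers known here; its nearest neighbour is compound 1, and the two measured steps are an at least 6.0-fold higher number from compound 1 to compound 2 (0.78 log units; beyond the scatter) and a 4.2-fold higher number from compound 1 to compound 3 (0.62 log units; beyond the scatter).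

Compound 4 `C/C=C/C(=O)OCCc1c(-c2ccccc2Cl)c2cc(Cl)ccc2[nH]c1=O` has not yet been measured. It differs from compound 3 in one place: prop-1-en-1-yl in place of 4-nitrophenyl on a carbonyl carbon. Neither measured step is this change. The step from compound 1 to compound 3 put a (4-nitrophenyl)carbonyl on the oxygen on a saturated carbon and raised the number modestly; compound 4 keeps a carbonyl on that oxygen but carries a prop-1-en-1-yl on it instead. Compound 4 is therefore expected to land between compound 1 and compound 3 or near compound 3, a step of about a 1.6-fold lower number from compound 3 to compound 4 (0.20 log units; within the scatter) that may well lie within the scatter. The estimate for compound 4 in this assay is 1000000 nM, with a range from 400000 nM to 2500000 nM.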

Compound 4, half-maximal cytotoxic concentration: 30000 nM
Compound 4: the middle estimate sits 33-fold (1.52 log units) above what was measured; measured number outside the range, below it.
By their numbers in this assay, from the lowest: compound 4; then compound 1; then compound 3. At a limit, above all of these: compound 2.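

In this assay the acyl group on this oxygen sets the direction of the change, not only its size. Placing (4-nitrophenyl)carbonyl on the oxygen on a saturated carbon raised the number (a 4.2-fold higher number from compound 1 to compound 3 (0.62 log units; beyond the scatter)), whereas (prop-1-en-1-yl)carbonyl on the same oxygen lowers it (a 13-fold lower number from compound 1 to compound 4 (1.10 log units; beyond the scatter)), so a carbonyl there does not by itself move the number upward, and the two groups are far from interchangeable (a 53-fold lower number from compound 3 to compound 4 (1.73 log units; beyond the scatter)). Nothing shown here gives a reason for this drop, and the feature of either group that carries it remains unexplained.

The compounds shown leave open whether the low number follows from the absence of the aromatic ring, from the absence of the nitro group, or from prop-1-en-1-yl itself. A plain phenyl or a saturated propyl on the same carbonyl would begin to separate these readings, and an amine in place of the nitro group on the phenyl ring would show whether the high number of compound 3 depends on that nitro group.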